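A few compounds are considered here, and "the series" means these few. Any claim that something is new, unique, unknown or untested is made for them only; others in the source may bear on it.

Working notes on the series. Compound 1 `Clc1ccc(COc2ccc(OCCOCCNC3CCCC3)cc2)cc1` is measured in a functional assay on SK-OV-3 cells (Homo sapiens) for inhibition, read by CCK-8 assay, with a stated time of 70 h (on this read-out lower numbers stand for stronger inhibition and higher numbers for weaker inhibition), at 7670 nM. Compound 3 `c1ccc(COc2ccc(OCCOCCNC3CCCCCC3)cc2)cc1` gives 7460 nM in this assay, a number within the scatter of compound 1. Compound 2 `COc1cc(OCCOCCNC2CCCC2)ccc1OCc1ccccc1` gives 44600 nM in this assay, a higher number than compound 1 and beyond the scatter. Compound 1 thus stands second highest of the three numbers, closest to compound 3 and furthest from compound 2. Compound 4 `O=[N+]([O-])c1ccccc1COc1ccc(OCCOCCNC2CCCC2)cc1` is not yet measured; it differs from compound 1 by 2-nitrophenyl in place of 4-chlorophenyl on a saturated chain carbon bound to an oxygen on an aromatic ring. For the measured compounds named here, no measured pair isolates this change. The expected step is a 1.3-fold higher number from compound 1 to compound 4 (0.12 log units; within the scatter), small, toward a higher number, within or only just beyond the scatter. In this assay compound 4 is estimated at 10000 nM, with a range from 4000 nM to 30000 nM.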

Compound 4, half-maximal inhibitory concentration: 5370 nM
Estimate against measurement, compound 4: 1.9-fold (0.27 log units) above, and the stated range covers the measured number.
By their numbers in this assay, from the lowest: compounds 4, 3 and 1 (each within the scatter of the next); then compound 2.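

In this assay, 2-nitrophenyl in place of 4-chlorophenyl gives a 1.4-fold lower number from compound 1 to compound 4 (0.15 log units; within the scatter) on a saturated chain carbon bound to an oxygen on an aromatic ring. This single pair shows that a group of 9 heavy atoms with 2 hydrogen-bond acceptors can replace one of 7 heavy atoms with none, with no step beyond the scatter. No measurement bears on a cause for this result. One pair cannot separate the loss of the chlorine from the entry of the nitro group. As far as these compounds go, whether a nitrile or a carboxylic acid on that phenyl ring would also leave the number within the scatter stays open.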